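The compounds below may be only part of what the source reports. "The series", "measured", "known", "first", "only" and "open" are said of these compounds alone.

Among the measured compounds shown here, compound 2 `CC(F)(F)c1cccc(N2C(=O)CSC2c2cccc(C(=O)NCCCCc3ccccc3)c2)c1` stands lowest of the two numbers so far in a functional assay on HOS cells (Homo sapiens) for inhibition, read by CCK-8 assay, with a stated time of 72 h, tested at 1 uM (a higher number here means more inhibition at the concentration tested (going by the name of the read-out), a lower number less inhibition), at 23%; its nearest neighbour, compound 1 `O=C(NCCCCc1ccccc1)c1cccc(C2SCC(=O)N2c2cccc(F)c2)c1`, gives 84% in this assay. For the measured compounds named here, the only measured step, a number 61 percentage points lower from compound 1 to compound 2 (beyond the scatter), concerns the group on the amide-type nitrogen in the ring, the same place that changes here. Compound 3 `COc1ccc(N2C(=O)CSC2c2cccc(C(=O)NCCCCc3ccccc3)c2)c(OC)c1` differs from compound 2 as follows: a group of 10 heavy atoms (8 carbon, 2 oxygen; one six-membered aromatic ring of carbon only) in place of a group of 10 heavy atoms (8 carbon, 2 fluorine; one six-membered aromatic ring of carbon only), on an amide-type nitrogen in a ring. Going by the values given here, that step leaves the group of compound 2 entirely, so the single step gives no direction for it. The step of a number 27 percentage points higher from compound 2 to compound 3 (beyond the scatter) is therefore an estimate only. Compound 3 is expected to give 50%, within 15% to 85%.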

Compound 3, a percentage reported as inhibition, at one concentration (the size of the read-out at that concentration, not a potency): 82%
Beside the measured number, compound 3's estimate is 32 percentage points below it, and the stated range covers the measured number.
By their numbers in this assay, from the lowest: compound 2; then compounds 3 and 1 (each within the scatter of the next).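

At the amide-type nitrogen in the ring, the aromatic group decides a great deal in this assay (a number 59 percentage points higher from compound 2 to compound 3 (beyond the scatter)), so the low number of compound 2 does not extend to every substituted phenyl group here. The step (a number 2 percentage points lower from compound 1 to compound 3 (within the scatter)) places 2,4-dimethoxyphenyl and 3-fluorophenyl level at this position, although they carry different substituents. No measurement shown explains the contrast with compound 2. Open, as far as these compounds go, is whether a single methoxy group matches the two in 2,4-dimethoxyphenyl, and whether an amine or a carboxylic acid on this aromatic ring keeps the number high.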